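The source may report more compounds than this note shows. Statements on the series, on what has been measured and on what is new or still open speak of the compounds shown alone.

Measured so far in a functional assay on ACHN cells (Homo sapiens) for antiproliferative activity, read by sulforhodamine B assay; a lower number here means a stronger inhibitor of growth, a higher number a weaker inhibitor of growth:
- Compound 1 `CC(C)(C)CCOc1cccc(O)c1C(=O)/C=C/c1ccc(O)cc1`: 3140 nM
- Compound 2 `O=C(/C=C/c1ccc(O)cc1)c1c(O)cccc1OCC1CCCCC1`: > 30000 nM (a limit)
- Compound 3 `CCCCOc1cccc(O)c1C(=O)/C=C/c1ccc(O)cc1`: > 30000 nM (a limit)

Compound 3 has only a limit and no number: the limit of > 30000 nM in this assay, at which 2 of the 3 values shown sit.

Compound 4 `CC(C)COc1cccc(O)c1C(=O)/C=C/c1ccc(O)cc1` differs from it in the chain (isopropyl in place of propyl on a saturated chain carbon bound to an oxygen on an aromatic ring), with isopropyl in place of propyl on a saturated chain carbon bound to an oxygen on an aromatic ring. Among the compounds with values here, two measured steps bear on this change, an at least 9.5-fold higher number from compound 1 to compound 3 (0.98 log units; beyond the scatter) and an at least 9.5-fold higher number from compound 1 to compound 2 (0.98 log units; beyond the scatter), and both lie beyond the scatter. A third, a step that the two limits leave unreadable from compound 2 to compound 3, cannot be read. Only compound 1 reaches a number, so little or no gain is expected in this assay. The expected step is an at least 1.2-fold lower number from compound 3 to compound 4 (0.07 log units; that floor lies within the scatter). Compound 4 is estimated at 25000 nM, within a range of 9000 nM to 50000 nM.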

Compound 4, concentration for 50% growth inhibition: 3290 nM
Estimate against measurement, compound 4: 7.6-fold (0.88 log units) above; measured number below the stated range.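

In this assay, the shape of the chain at this place, and not only its size, now separates the compounds: isopropyl in place of propyl gives an at least 9.1-fold lower number from compound 3 to compound 4 (0.95 log units; beyond the scatter), and isopropyl in place of cyclohexyl gives an at least 9.1-fold lower number from compound 2 to compound 4 (0.95 log units; beyond the scatter). Isopropyl and neopentyl cannot be told apart, with a 1.0-fold higher number from compound 1 to compound 4 (0.02 log units; within the scatter), so two branched chains reach a number, while compound 2, which also carries a ring on the chain, goes against any simple rule on branching. The first two steps are floors and not sizes: the limit of > 30000 nM in this assay, at which 2 of the 4 values shown sit.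

The compounds shown leave open whether a longer unbranched chain also stays at the limit. They also leave open whether an amine or a carboxylic acid on the chain would keep a number of this order.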